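Moving the methoxy group: from compound 2 to compound 3

The source may hold more compounds than are shown below. What is called first, only, known or untested is meant among the compounds shown, and "the series" means these compounds.

In a functional assay on WM1361 cells (Homo sapiens) for inhibition, read by MTT assay, with a stated time of 24 h (a higher number here means a weaker inhibitor, a lower number a stronger inhibitor), compound 1 `O=c1oc2ccccc2c(N2CCN(c3ccccc3)CC2)c1CO` gives > 50000 nM as a limit and not a number. Compound 2 `COc1ccccc1N1CCN(c2c(CO)c(=O)oc3ccccc23)CC1` gives > 50000 nM as a limit and not a number as well. All that is known of where compound 2 stands is thus (the limit of > 50000 nM in this assay, at which 2 of the 2 values shown sit), with no measured number to start from.

Compound 3 `COc1ccc(N2CCN(c3c(CO)c(=O)oc4ccccc34)CC2)cc1` keeps the shared core and carries 4-methoxyphenyl in place of 2-methoxyphenyl on an amine nitrogen in a ring.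

For the measured compounds named here, the only measured step that bears on this change is a step that the two limits leave unreadable from compound 1 to compound 2, where methoxy came in place of hydrogen on an aromatic carbon. It has no readable size, so it offers no measured effect of a methoxy group to carry over. No step beyond the scatter is therefore expected in this assay, in either direction. The estimated move is a number no higher from compound 2 to compound 3 (the limit leaves the size open), and a report of only a limit is the likeliest outcome. Compound 3 is expected at about 50000 nM, with an estimated range from 20000 nM to 100000 nM.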

Compound 3, half-maximal inhibitory concentration: 40400 nM
Estimate against measurement, compound 3: 1.2-fold (0.09 log units) above, and the stated range covers the measured number.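

In this assay, for the compounds shown here, compound 3, with 4-methoxyphenyl in place of 2-methoxyphenyl on an amine nitrogen in a ring, is the one compound of the three that returns a number and not a limit, while the other two stay at that limit: the limit of > 50000 nM in this assay, at which 2 of the 3 values shown sit. Moving the methoxy group reads as an at least 1.2-fold lower number from compound 2 to compound 3 (0.09 log units; that floor lies within the scatter), and methoxy in place of hydrogen at this new position reads as an at least 1.2-fold lower number from compound 1 to compound 3 (0.09 log units; that floor lies within the scatter); both are floors only, so the true size of each step stays open. The step between the two compounds at the limit cannot be read, so the series gives a number for the 4-methoxyphenyl compound but no size for any effect of the 2-methoxyphenyl group.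

Still open, as far as these compounds go, is whether another group in the place of the methoxy, such as a dimethylamino group or a carboxylic acid, would give a number clearly apart from that of compound 3. Also open, from the compounds shown here alone, is whether any change to the shared core, rather than to the aromatic ring on the amine nitrogen, would move the number beyond the scatter.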